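This account rests on a few compounds, and the source may have more. Where it says the series, first, only, none or still open, it means among the compounds named here.

Working notes on the series. Compound 1 `COc1cc(-c2cc(C(=O)O)c3ccccc3n2)ccc1OCC(=O)Nc1ccccc1F` and compound 2 `COc1cc(-c2cc(C(=O)O)c3ccccc3n2)ccc1OCC(=O)Nc1cccc(Cl)c1` share one core and differ only in the aryl group on the amide-type nitrogen. In an ADME assay on HaCaT cells (Homo sapiens) for inhibition (a lower number here means a stronger inhibitor, a higher number a weaker inhibitor), compound 1 gives 161000 nM, and compound 2 gives 192000 nM. Among the compounds with values here, compound 1 thus holds the lowest of the two numbers measured in this assay so far, with compound 2 nearest to it; the step of a 1.2-fold higher number from compound 1 to compound 2 (0.08 log units; within the scatter) is within the scatter, so the two numbers are not ordered against each other.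

The next compound, compound 3 `COc1cc(-c2cc(C(=O)O)c3ccccc3n2)ccc1OCC(=O)Nc1ccc(Cl)cc1`, again keeps the core and changes the same aryl group: 4-chlorophenyl in place of 2-fluorophenyl on an amide-type nitrogen. Within the data shown here, the only measured step that bears on this change is the one from compound 1 to compound 2, a 1.2-fold higher number from compound 1 to compound 2 (0.08 log units; within the scatter), which also swapped a fluorophenyl for a chlorophenyl on that nitrogen and moved the number by less than the scatter. On that basis no step beyond the scatter is expected in this assay from compound 1 to compound 3, that is a 1.1-fold higher number from compound 1 to compound 3 (0.05 log units; within the scatter). Compound 3 is therefore estimated at 180000 nM, within a range of 90000 nM to 360000 nM.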

Compound 3, half-maximal inhibitory concentration: > 300000 nM
Compound 3 ended at the assay's limit; the forecaster's own chance of this, stated with the estimate: 20%; middle value at least 1.6-fold (0.22 log units) away from the limit.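

In this assay compound 3 gives > 300000 nM, which is a limit of the assay and not a number. With 4-chlorophenyl on the amide-type nitrogen, the steps can therefore be read only as floors, an at least 1.8-fold higher number from compound 1 to compound 3 (0.27 log units; that floor lies within the scatter) and an at least 1.5-fold higher number from compound 2 to compound 3 (0.19 log units; that floor lies within the scatter); neither floor establishes a separation beyond the scatter, but neither rules out a larger step. The earlier pair gave two numbers that could not be ordered, whereas this position now also holds a compound whose true number cannot be placed, and the changes at this position reach the top of the readable range: the limit of > 300000 nM in this assay, at which 1 of the 3 values shown sits.

On these data alone, how far compound 3 lies past that limit remains open, and with it whether 4-chlorophenyl truly separates from 2-fluorophenyl or 3-chlorophenyl in this assay. Also open, as far as these compounds go, is whether a nitrile or an amine in place of the halogen on the phenyl ring, or a pyridine in place of the phenyl ring itself, would give a number clearly separated from those of compound 1 and compound 2.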